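Acyl swaps on the shared core: compound 3 to compound 4

This account rests on a few compounds, and the source may have more. Where it says the series, first, only, none or still open, it means among the compounds named here.

Measured in an ADME assay on HepG2 2.2.15 cells (Homo sapiens) for cytotoxicity; on this read-out higher numbers stand for lower toxicity in this test and lower numbers for higher toxicity in this test:
- compound 1 `CCCCC(=O)OCCc1c(-c2ccccc2Cl)c2cc(Cl)ccc2[nH]c1=O`: 200000 nM
- compound 2 `O=C(CCC1CCCCC1)OCCc1c(-c2ccccc2Cl)c2cc(Cl)ccc2[nH]c1=O`: 160000 nM
- compound 3 `O=C(/C=C/c1ccccc1)OCCc1c(-c2ccccc2Cl)c2cc(Cl)ccc2[nH]c1=O`: 230000 nM

Compound 3 does not separate from the other two measured compounds, since a 1.2-fold higher number from compound 1 to compound 3 (0.06 log units; within the scatter) and a 1.4-fold higher number from compound 2 to compound 3 (0.16 log units; within the scatter). No order can be drawn among the three.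

The next compound is compound 4 `COc1ccc(/C=C/C(=O)OCCc2c(-c3ccccc3Cl)c3cc(Cl)ccc3[nH]c2=O)cc1OC`. It carries 3,4-dimethoxyphenyl in place of phenyl on a double-bonded chain carbon bound to a double-bonded chain carbon.

Among the measured compounds shown here, three measured steps bear on this change, all of them replacing the group on the carbonyl side of the shared core. Alongside the two above stands a 1.3-fold lower number from compound 1 to compound 2 (0.10 log units; within the scatter). Each stays within the scatter, even though the groups exchanged differ widely. For the measured compounds named here, none of the measured compounds carries a substituent on the phenyl ring of compound 3, so the read-across is indirect. No step beyond the scatter is therefore expected in this assay, and no direction is favoured.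

The expected step is a 1.2-fold lower number from compound 3 to compound 4 (0.06 log units; within the scatter).

Compound 4 is estimated at 200000 nM, with an expected range of 100000 nM to 400000 nM.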

Compound 4, half-maximal cytotoxic concentration: > 1200000 nM
Compound 4: only a limit was reported; the forecaster's own chance of this, stated with the estimate: 15%; at least 6.0-fold (0.77 log units) between middle value and limit.
By their numbers in this assay, from the lowest: compounds 2, 1 and 3 (each within the scatter of the next). At a limit, above all of these: compound 4.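

In this assay, swapping the whole acyl group had left the read-out within the scatter, whereas substitution on the phenyl of compound 3 does not: an at least 5.2-fold higher number from compound 3 to compound 4 (0.71 log units; beyond the scatter). The saturated acyl groups give the same picture, with an at least 7.5-fold higher number from compound 2 to compound 4 (0.87 log units; beyond the scatter) and an at least 6.0-fold higher number from compound 1 to compound 4 (0.77 log units; beyond the scatter), which makes the 2-(3,4-dimethoxyphenyl)ethenyl group the only change among the compounds shown to go beyond the scatter, in the direction of lower toxicity in this test. The value of compound 4 is a limit and not a number: the limit of > 1200000 nM in this assay, at which 1 of the 4 values shown sits.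

The compounds shown leave open whether both methoxy groups are needed, and whether a hydroxyl, a fluoro or an amine on that phenyl ring would give a step of the same kind. They also leave open how far the read-out of compound 4 actually extends, and whether the 3,4-dimethoxyphenyl group would act the same way on a saturated chain in place of the double-bonded one.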